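The Same Side-Chain Swap on a Second Core

The source may hold more compounds than are shown below. What is called first, only, known or untested is meant among the compounds shown, and "the series" means these compounds.

Compound 3 `CCOC(=O)CN(C)CC#Cc1cc2c(Nc3ccc(OCc4cccc(F)c4)c(Cl)c3)ncnc2s1` is tested in an ADME assay on HepG2 cells (Homo sapiens) for cytotoxicity (on this read-out higher numbers stand for lower toxicity in this test and lower numbers for higher toxicity in this test), where compound 3 gives > 28 uM, which is a limit of the assay and not a number. Compound 4 `CCCN(CC#Cc1cc2c(Nc3ccc(OCc4cccc(F)c4)c(Cl)c3)ncnc2s1)CCC` differs from it by one change, dipropylamino in place of ((ethoxycarbonyl)methyl)(methyl)amino on a saturated chain carbon bound to a triple-bonded carbon.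

The same swap has been measured once, on a different core. Compound 1 `CCOC(=O)CN(C)CC#Cc1cc2ncnc(Nc3ccc(OCc4cccc(F)c4)c(Cl)c3)c2s1` gives 26 uM in this assay, and compound 2 `CCCN(CC#Cc1cc2ncnc(Nc3ccc(OCc4cccc(F)c4)c(Cl)c3)c2s1)CCC` gives 26.5 uM. That is a 1.0-fold higher number from compound 1 to compound 2 (0.01 log units; within the scatter), so the swap left the read-out unchanged there. Among the compounds with values here, this single pair is the only guide, and it points to no shift beyond the scatter here either. The expected outcome is therefore a number no higher from compound 3 to compound 4 (the limit leaves the size open). The estimate for compound 4 is 28 uM, with an expected range from 17 uM to 42 uM.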

Compound 4, half-maximal toxic concentration: 17 uM
The estimate for compound 4 lay 1.6-fold (0.22 log units) above the measured number; low and high end bracket the measured number.
By their numbers in this assay, from the lowest: compounds 4, 1 and 2 (each within the scatter of the next). At a limit, above all of these: compound 3.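

On the second core, dipropylamino in place of ((ethoxycarbonyl)methyl)(methyl)amino gives an at least 1.6-fold lower number from compound 3 to compound 4 (0.21 log units; that floor lies within the scatter) in this assay. Compound 3 gives > 28 uM, which is a limit of the assay and not a number, so this pair sets only a floor on the size of the step, whereas compound 4 adds a measured value on this core. The change has now been read on two cores, but the comparison between them stays unsettled: the same change on two cores in this assay, a 1.0-fold higher number (0.01 log units; within the scatter) from compound 1 to compound 2 and an at least 1.6-fold lower number (0.21 log units; that floor lies within the scatter) from compound 3 to compound 4; the limit leaves it open whether they differ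

As far as these compounds go, the true size of the step from the ethoxycarbonyl side chain to dipropylamino on this core remains open. So does the read-out with a carboxylic acid in place of the ethyl ester, or with a ring amine such as morpholine in place of dipropylamino, on either core.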